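The source may report more compounds than this note shows. Statements on the series, on what has been measured and on what is new or still open speak of the compounds shown alone.

In a functional assay on PC-3 cells (Homo sapiens) for antiproliferative activity, read by MTT assay (a higher number here means a weaker inhibitor, a lower number a stronger inhibitor), three compounds that share one core have been measured. Compound 1 `Cn1c(=O)c(=O)n(C2CCCC2)c2nc(N/N=C/c3ccc(Cl)cc3)ncc21` gives 8420 nM. Compound 2 `Cn1c(=O)c(=O)n(C2CCCC2)c2nc(N/N=C/c3ccc(S(C)(=O)=O)cc3)ncc21` gives 26600 nM. Compound 3 `Cc1cc(C)c(/C=N/Nc2ncc3c(n2)n(C2CCCC2)c(=O)c(=O)n3C)c(C)c1` gives 13900 nM. Among these three numbers compound 3 stands second highest: the gap to its nearest neighbour is a 1.7-fold higher number from compound 1 to compound 3 (0.22 log units; within the scatter), and the gap to the furthest is a 1.9-fold lower number from compound 2 to compound 3 (0.28 log units; within the scatter), both within the usual scatter, so no order among these three can be read. Among the compounds with values here, only the step of a 3.2-fold higher number from compound 1 to compound 2 (0.50 log units; beyond the scatter), an exchange of methylsulfonyl for chloro on an aromatic carbon, reaches beyond the scatter.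

Compound 4 `Cn1c(=O)c(=O)n(C2CCCC2)c2nc(N/N=C/c3ccc(F)cc3Br)ncc21` differs from compound 3 in one place: 2-bromo-4-fluorophenyl in place of 2,4,6-trimethylphenyl on a carbon with a double bond to nitrogen. Within the data shown here, two measured steps swap the whole aromatic group on that same carbon, a 1.7-fold higher number from compound 1 to compound 3 (0.22 log units; within the scatter) and a 1.9-fold lower number from compound 2 to compound 3 (0.28 log units; within the scatter), and both were small; the single step that changed a substituent on such a ring, a 3.2-fold higher number from compound 1 to compound 2 (0.50 log units; beyond the scatter), was modest. A change of this kind is therefore expected to move the number little, if at all beyond the scatter, with compound 1, which also carries a halogen on its ring and gives 8420 nM, suggesting the lower side of the range seen so far. The estimated step is a 1.4-fold lower number from compound 3 to compound 4 (0.14 log units; within the scatter). Compound 4 is accordingly expected to give 10000 nM, within a range from 4000 nM to 25000 nM.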

Compound 4, half-maximal inhibitory concentration: 9250 nM
Compound 4: middle estimate off by 1.1-fold (0.03 log units), on the high side; the measured number falls inside the stated range.
By their numbers in this assay, from the lowest: compounds 1, 4, 3 and 2 (each within the scatter of the next, the first and the last beyond it).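

In this assay, the 2-bromo-4-fluorophenyl group of compound 4 cannot be told apart from either the 2,4,6-trimethylphenyl group (a 1.5-fold lower number from compound 3 to compound 4 (0.18 log units; within the scatter)) or the 4-chlorophenyl group (a 1.1-fold higher number from compound 1 to compound 4 (0.04 log units; within the scatter)), so a ring carrying two different halogens reads the same as one carrying three methyl groups or a single chlorine on this carbon with a double bond to nitrogen. Within the data shown here, the 4-(methylsulfonyl)phenyl group is the only one that separates from the halogen-bearing rings, with a 2.9-fold lower number from compound 2 to compound 4 (0.46 log units; beyond the scatter) adding a second step beyond the scatter to the one already seen from compound 1. Compound 3 goes against a clean split. It remains within the scatter of compound 2. Nothing measured here explains why the numbers fall this way.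

As far as these compounds go, all four groups at this place are substituted benzene rings, so it remains open what an amine or a carboxylic acid on the ring would do, or a longer chain in place of the ring. From the compounds shown here alone, it is also open whether any group here can give a number well under that of compound 1 (8420 nM).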